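A few compounds are considered here, and "the series" means these few. Any claim that something is new, unique, unknown or untested is made for them only; others in the source may bear on it.

Of the compounds shown here, three built on one shared core have so far been read in a functional assay on HCT-116 cells (Homo sapiens) for antiproliferative activity, read by CCK-8 assay, with a stated time of 72 h; on this read-out lower numbers stand for stronger inhibition and higher numbers for weaker inhibition. Compound 1 `Nc1ccccc1NC(=O)c1ccc(COc2ccc(Br)cc2)cc1` gives only a limit of the assay, > 32000 nM. Compound 2 `CCc1ccc(OCc2ccc(C(=O)Nc3ccccc3N)cc2)cc1` gives 4830 nM. Compound 3 `CC(C)c1ccc(OCc2ccc(C(=O)Nc3ccccc3N)cc2)cc1` gives 4570 nM, which places it level with compound 2. The next compound, compound 4 `CCCc1ccc(OCc2ccc(C(=O)Nc3ccccc3N)cc2)cc1`, carries propyl in place of isopropyl on an aromatic carbon, para to a large group: propyl in place of isopropyl on an aromatic carbon. Exchanging bromo for an alkyl group mattered, with an at least 6.6-fold lower number from compound 1 to compound 2 (0.82 log units; beyond the scatter) and an at least 7.0-fold lower number from compound 1 to compound 3 (0.84 log units; beyond the scatter), both beyond the scatter. Those steps start from bromo, however, so they bear on this change less closely than the step between the two alkyl groups. No shift beyond the scatter, in either direction, is expected in this assay because a 1.1-fold lower number from compound 2 to compound 3 (0.02 log units; within the scatter) stayed within it. The expected change is a 1.0-fold lower number from compound 3 to compound 4 (0.01 log units; within the scatter). For compound 4 the estimated value is 4500 nM, with an expected range from 2000 nM to 11000 nM.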

Compound 4, half-maximal inhibitory concentration: 3230 nM
Compound 4: the middle estimate sits 1.4-fold (0.14 log units) above what was measured, and the stated range covers the measured number.
By their numbers in this assay, from the lowest: compounds 4, 3 and 2 (each within the scatter of the next). At a limit, above all of these: compound 1.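

In this assay, rearranging the same three carbons from isopropyl to propyl at this position, para to a large group, gives a 1.4-fold lower number from compound 3 to compound 4 (0.15 log units; within the scatter), and adding a methyl to the ethyl chain to make propyl gives a 1.5-fold lower number from compound 2 to compound 4 (0.17 log units; within the scatter), so a straight chain and a branched one stand level here, as ethyl does. Propyl in place of bromo gives an at least 9.9-fold lower number from compound 1 to compound 4 (0.99 log units; beyond the scatter), a third alkyl group to show a step beyond the scatter from bromo. Compound 1 stands at a limit of the assay, not at a number: the limit of > 32000 nM in this assay, at which 1 of the 4 values shown sits.

The compounds shown leave open whether a longer chain such as butyl would stay at this level. They also leave open what a methoxy group or an amine at this position would give.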